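The source may report more compounds than this note shows. Statements on the series, on what has been measured and on what is new or still open speak of the compounds shown alone.

Measured so far in a toxicity assay on L02 cells (Homo sapiens) for cytotoxicity, read by MTT assay, with a stated time of 24 h; on this read-out lower numbers stand for higher toxicity in this test and higher numbers for lower toxicity in this test:
Compound 1 `CCCCS(=O)(=O)Oc1ccc(/C=C/C(=O)Nc2ccccc2)cc1OC` gives 3320 nM.
Compound 2 `CCCCOC(=O)/C=C/c1ccc(OS(=O)(=O)c2ccc(Cl)cc2)c(OC)c1` gives 14000 nM.
Compound 3 `CCCCS(=O)(=O)Oc1ccc(/C=C/C(=O)OCC(C)C)cc1OC` gives 63800 nM.

Compound 2 stands second highest of the three numbers; compound 1 gives a lower number and compound 3 a higher one, both gaps beyond the scatter. Compound 4 `COc1cc(/C=C/C(=O)Nc2cccc(C)c2)ccc1OS(=O)(=O)c1ccc(Cl)cc1` differs from compound 2 by (3-methylphenyl)amino in place of butoxy on a carbonyl carbon. Within the data shown here, the one measured step that bears on this is the reverse exchange at the same place, a 19-fold higher number from compound 1 to compound 3 (1.28 log units; beyond the scatter), where the group on the carbonyl carbon went from anilino to isobutoxy and the number rose sharply. Putting an arylamino group back onto the carbonyl carbon is therefore expected to lower the number in this assay by a comparable amount, an expected step of a 9.3-fold lower number from compound 2 to compound 4 (0.97 log units; beyond the scatter). Compound 4 is estimated at 1500 nM, within a range of 450 nM to 5000 nM.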

Compound 4, half-maximal cytotoxic concentration: 73500 nM
The estimate for compound 4 lay 49-fold (1.69 log units) below the measured number, and the stated range ends below it.
By their numbers in this assay, from the lowest: compound 1; then compound 2; then compounds 3 and 4 (each within the scatter of the next).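

In this assay butoxy to (3-methylphenyl)amino on a carbonyl carbon gives a 5.3-fold higher number from compound 2 to compound 4 (0.72 log units; beyond the scatter) and anilino to isobutoxy at the same place gives a 19-fold higher number from compound 1 to compound 3 (1.28 log units; beyond the scatter) as well. Exchange between an alkoxy and an arylamino group here therefore has no single direction across these compounds, and its outcome differs with the rest of the molecule. Nothing available explains this reversal.

Open, on these data alone, is whether the reversal follows the group on the sulfonyl or the methyl of the (3-methylphenyl)amino group. Also open, as far as these compounds go, is how a benzylamino group or a carboxylic acid at this carbonyl carbon would read.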